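Removing One Hydroxyethoxy Arm from an Ethenyl Amide Antagonist

A few compounds are considered here, and "the series" means these few. Any claim that something is new, unique, unknown or untested is made for them only; others in the source may bear on it.

Of the compounds shown here, two share a core and have been tested in a functional assay on C6 cells for antagonist activity at prostaglandin E2 receptor EP4 subtype (Homo sapiens), read by TR-FRET and cAMP accumulation, with stated times of 10 min and 40 min; on this read-out lower numbers stand for stronger inhibition and higher numbers for weaker inhibition. Compound 1 `Cc1cc2ccccc2n1CCNC(=O)/C=C/c1ccc(OCCCO)cc1` carries a single 3-hydroxypropoxy group on its aromatic ring, and in this assay compound 1 gives 5.96 nM. Compound 2 `Cc1cc2ccccc2n1CCNC(=O)/C=C/c1ccc(OCCO)c(OCCO)c1` instead carries two 2-hydroxyethoxy groups, and in this assay compound 2 gives 7.13 nM. These two numbers lie within the scatter of each other, so the assay cannot tell the two compounds apart. Compound 3 `Cc1cc2ccccc2n1CCNC(=O)/C=C/c1ccc(OCCO)cc1` is compound 2 with one arm taken away: hydrogen in place of 2-hydroxyethoxy on an aromatic carbon, leaving one 2-hydroxyethoxy group in place. Within the data shown here, no step between measured compounds covers this exact change, and compound 1 with its single hydroxy-terminated chain shows that one such arm is enough for the potency seen. Compound 3 is therefore expected to stay close to compound 2, with a step of a 1.1-fold lower number from compound 2 to compound 3 (0.04 log units; within the scatter) that amounts to nothing beyond the scatter. The estimate for compound 3 in this assay is 6.5 nM, with a range from 3 nM to 14 nM.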

Compound 3, antagonist equilibrium constant: 7.58 nM
Estimate against measurement, compound 3: 1.2-fold (0.07 log units) below; low and high end bracket the measured number.
By their numbers in this assay, from the lowest: compounds 1, 2 and 3 (each within the scatter of the next).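

Replacing the second 2-hydroxyethoxy group with hydrogen gives a 1.1-fold higher number from compound 2 to compound 3 (0.03 log units; within the scatter), so in this assay the two compounds cannot be told apart, and this arm, ortho to the remaining 2-hydroxyethoxy group, can be removed without a difference the assay can detect. The single chain can also differ: with hydroxy in place of hydroxymethyl, turning 3-hydroxypropoxy into 2-hydroxyethoxy, the result is a 1.3-fold higher number from compound 1 to compound 3 (0.10 log units; within the scatter), so these two chain lengths cannot be separated either. Among these three compounds, neither the second arm nor the extra chain carbon shows a measurable effect on the number.

Still open, from the compounds shown here alone, is whether the remaining chain matters at all, and whether an amine or a carboxylic acid at its end, or a longer chain, would shift the number. Nothing available here offers a reason for these results.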